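The compounds below may be only part of what the source reports. "The series", "measured", "known", "first", "only" and "open" are said of these compounds alone.

Three ureas with a shared core have been tested in an ADME assay on isolated protein for inhibition of sodium-dependent dopamine transporter (Homo sapiens), tested at 10 uM; a higher number here means more inhibition at the concentration tested (going by the name of the read-out), a lower number less inhibition. Compound 1 `O=C(NCCCCC(c1ccc(F)cc1)c1ccc(F)cc1)Nc1ccc(Cl)c(C(F)(F)F)c1` gives 90%, compound 2 `COc1ccc(C(CCCCNC(=O)Nc2ccc(Cl)c(C(F)(F)F)c2)c2ccc(OC)cc2)cc1` gives 75%, and compound 3 `CN(CCCCC(c1ccc(F)cc1)c1ccc(F)cc1)C(=O)Nc1ccc(Cl)c(C(F)(F)F)c1` gives 73%. Compound 3 thus lies beyond the scatter below compound 1, while its gap to compound 2 is within the scatter. The step from compound 1 to compound 3 is a methyl in place of hydrogen on an amide-type nitrogen, and it brought a number 17 percentage points lower from compound 1 to compound 3 (beyond the scatter).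

Compound 4 `CN(CCCCC(c1ccc(F)cc1)c1ccc(F)cc1)C(=O)N(C)c1ccc(Cl)c(C(F)(F)F)c1` carries the same kind of change once more: methyl in place of hydrogen on an amide-type nitrogen. Within the data shown here, only the single step from compound 1 to compound 3 bears on this, and it was modest. A further decrease of roughly that size is expected, giving a number 18 percentage points lower from compound 3 to compound 4 (beyond the scatter) and an estimate for compound 4 of 55%, ranging from 30% to 75%.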

Compound 4, a percentage reported as inhibition, at one concentration (the size of the read-out at that concentration, not a potency): 26%
Beside the measured number, compound 4's estimate is 29 percentage points above it; measured number outside the range, below it.
By their numbers in this assay, from the lowest: compound 4; then compounds 3 and 2 (each within the scatter of the next); then compound 1.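

In this assay, placing a methyl on the amide-type nitrogen whose other neighbours are an aromatic carbon and a carbonyl carbon gave a number 47 percentage points lower from compound 3 to compound 4 (beyond the scatter), a large step. The same kind of change on the other amide-type nitrogen gave only a modest step, a number 17 percentage points lower from compound 1 to compound 3 (beyond the scatter), so its size is not the same at both places in this series. Nothing available explains this difference. Still open, going by these compounds, is whether the large step at this nitrogen depends on the methyl already present on the other nitrogen. Also open, on these data alone, is how an ethyl group at this nitrogen would compare.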